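Trimming an acyloxymethyl carbamate to a methyl carbamate

A few compounds are considered here, and "the series" means these few. Any claim that something is new, unique, unknown or untested is made for them only; others in the source may bear on it.

The measured compounds:
compound 1, `CC(C)C(=O)OCOC(=O)N1CCN(C(=O)c2nc(Nc3cc(C4CC4)[nH]n3)c3cc(Cl)ccc3n2)C[C@H]1C`, 51.6%
compound 2, `C[C@@H]1CN(C(=O)c2nc(Nc3cc(C4CC4)[nH]n3)c3cc(Cl)ccc3n2)CCN1C(=O)OCc1ccccc1`, 74%

In an assay for inhibition of serine/threonine-protein kinase PAK 4 (Homo sapiens), read by FRET and Z'-LYTE, with a stated time of 60 min, tested at 5 uM, in the presence of a further agent that is not named here (a higher number here means a stronger effect of the compound at the concentration tested, a lower number a weaker effect), compound 1 gives 51.6%, the lower of the two numbers at hand. Among the compounds with values here, compound 2 gives 74%, and the one measured step, a number 22.4 percentage points higher from compound 1 to compound 2 (beyond the scatter), is the only comparison available. Compound 3, `COC(=O)N1CCN(C(=O)c2nc(Nc3cc(C4CC4)[nH]n3)c3cc(Cl)ccc3n2)C[C@H]1C`, has not been measured in this assay. Its difference from compound 1 is hydrogen in place of (isopropylcarbonyl)oxy on a saturated chain carbon bound to an oxygen next to a carbonyl group.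

The step from compound 1 to compound 2 shows that reworking this position can move the read-out beyond the scatter, but that step put a phenyl in place of the (isopropylcarbonyl)oxy group, whereas compound 3 puts hydrogen there, so it bears on the change only loosely. With nothing closer to lean on, compound 3 is expected to land a little above compound 1, the step of a number 8.4 percentage points higher from compound 1 to compound 3 (within the scatter) being the estimate, with a wide range. The estimate for compound 3 is 60%, between 35% and 85%.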

Compound 3, a percentage reported as inhibition, at one concentration (the size of the read-out at that concentration, not a potency): 89.6%
The estimate for compound 3 lay 29.6 percentage points below the measured number, outside the stated range (above it).
By their numbers in this assay, from the lowest: compound 1; then compound 2; then compound 3.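

In this assay, cutting the (((isopropylcarbonyl)oxy)methoxy)carbonyl group back to methoxycarbonyl gives a number 38 percentage points higher from compound 1 to compound 3 (beyond the scatter), so the (isopropylcarbonyl)oxy group is not needed for the read-out at this position, and its loss brings a large gain rather than a cost. Hydrogen in place of phenyl on the same saturated chain carbon gives a number 15.6 percentage points higher from compound 2 to compound 3 (beyond the scatter), which shows that the earlier gain with phenyl did not mark the best choice here: both groups placed on this carbon stand below plain hydrogen, with (isopropylcarbonyl)oxy the lower of the two. No measurement at hand offers a reason for this order among the three compounds.

The compounds shown leave open whether a short chain such as ethyl, a longer chain, or an amine on this carbon would hold the number reached with hydrogen or lower it, so three compounds fix no trend with group size. They also leave open how far these differences carry over into potency, since each number is a read-out at a single concentration.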